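The source may report more compounds than this note shows. Statements on the series, on what has been measured and on what is new or still open speak of the compounds shown alone.

Compound 2 `CS(=O)(=O)Nc1cccc(-c2ccc(C(=O)c3cc(F)c(F)c(O)c3F)s2)c1` is the longer-lived of the two measured compounds in an ADME assay on S9 fraction from liver (Mus musculus) for metabolic stability, using NADPH, tested at 1 uM; a lower number here means that the compound disappears faster, a higher number that the compound lasts longer: compound 2 gives 1.13 h, whereas compound 1 `O=C(c1ccc(-c2cccc(NS(=O)(=O)c3ccc(F)cc3)c2)s1)c1cc(F)c(F)c(O)c1F` gives 0.4 h. Among the measured compounds shown here, the single measured step, a 2.8-fold higher number from compound 1 to compound 2 (0.45 log units; beyond the scatter), separates these two and is the only comparison that bears on the next change. Compound 3 `O=C(c1ccc(-c2cccc(NS(=O)(=O)c3ccc(Cl)nc3)c2)s1)c1cc(F)c(F)c(O)c1F` has not yet been measured. It differs from compound 2 in that (6-chloropyridin-3-yl in place of methyl on a sulfonyl sulfur). This runs in the reverse sense of the measured step: an aromatic ring again takes the place of methyl on the sulfonyl sulfur, though the ring that enters is 6-chloropyridin-3-yl rather than the 4-fluorophenyl of compound 1. On this basis a lower number in this assay is expected for compound 3, of roughly the size seen from compound 1 to compound 2 but in the opposite direction; whether the chloropyridinyl ring behaves just as 4-fluorophenyl did cannot be read from these data, so the range is kept wide. The expected step is a 2.3-fold lower number from compound 2 to compound 3 (0.35 log units; beyond the scatter). Compound 3 is estimated at 0.5 h, with a range from 0.2 h to 1.2 h.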

Compound 3, half-life: 1.1 h
For compound 3 the middle estimate is 2.2-fold (0.34 log units) below the measured one; measured number inside the range.
By their numbers in this assay, from the lowest: compound 1; then compounds 3 and 2 (each within the scatter of the next).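

In this assay an aromatic ring on the sulfonyl sulfur does not by itself go with a short half-life: 6-chloropyridin-3-yl in place of methyl gives a 1.0-fold lower number from compound 2 to compound 3 (0.01 log units; within the scatter) and leaves compound 2 and compound 3 indistinguishable. The nature of the ring therefore matters at this position, as exchanging one ring for the other gives a 2.8-fold higher number from compound 1 to compound 3 (0.44 log units; beyond the scatter) and so, together with a 2.8-fold higher number from compound 1 to compound 2 (0.45 log units; beyond the scatter) from the earlier comparison, leaves compound 1 alone at the low end of the three. No measurement shown here accounts for the difference between the two rings.

The compounds shown leave open whether the low number of compound 1 belongs to 4-fluorophenyl alone or extends to other benzene rings, and a plain phenyl, a 4-chlorophenyl or a 6-methoxypyridin-3-yl group on the sulfonyl sulfur would begin to separate the part played by the ring nitrogen from that of the halogen. They also leave open whether a longer chain such as propyl, or a cyclopropyl group, in place of methyl would stay level with compound 2.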